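The source may hold more compounds than are shown below. What is called first, only, known or untested is meant among the compounds shown, and "the series" means these compounds.

In a functional assay on HCT-116 cells (Homo sapiens) (a higher number here means a weaker inhibitor of growth, a lower number a stronger inhibitor of growth), compound 1 `COc1cccc(-c2cc(=O)c3ccc(C)nc3[nH]2)c1` gives 46.8 nM and compound 2 `COc1cccc(-c2cc(O)c3c(C)cc(C)nc3n2)c1` gives 407 nM as the higher of the two numbers, a gap beyond the usual scatter. Compound 3 `COc1cccc(-c2cc(O)c3c(C)ccnc3n2)c1` differs from compound 2 in one place: the change hydrogen in place of methyl on an aromatic carbon puts hydrogen in place of methyl on an aromatic carbon, next to the ring nitrogen. Within the data shown here, no measured pair shows this change alone, so the size of the step is uncertain. In this assay the estimated 1.1-fold higher number from compound 2 to compound 3 (0.04 log units; within the scatter) is expected to stay within the scatter, with no clear direction. For compound 3 the estimated value is 450 nM within an expected range of 130 nM to 1500 nM for this measurement.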

Compound 3, concentration for 50% growth inhibition: 44.7 nM
For compound 3 the middle estimate is 10-fold (1.00 log units) above the measured one; the whole stated range lies above it.
By their numbers in this assay, from the lowest: compounds 3 and 1 (each within the scatter of the next); then compound 2.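

In this assay hydrogen in place of methyl on the aromatic carbon next to the ring nitrogen gives a 9.1-fold lower number from compound 2 to compound 3 (0.96 log units; beyond the scatter) and so marks this single position as one that matters for growth inhibition in these cells. Losing just one methyl group, a single carbon, is enough to move the number beyond the scatter. Nothing measured here explains the step. Only methyl and hydrogen are shown at this carbon, so it stays open how the number depends on the group there; a fluorine atom, an amine or an ethyl chain would help settle that.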